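This account rests on a few compounds, and the source may have more. Where it says the series, first, only, none or still open, it means among the compounds named here.

Compound 1 `COc1ccc(C2N=C(SCc3ccc(Cl)cc3)NC(C)=C2C(=O)Nc2ccc(Br)cc2)cc1`, compound 2 `COc1ccc(C2N=C(SCc3ccc(F)cc3)NC(C)=C2C(=O)Nc2ccc(Br)cc2)cc1` and compound 3 `CC1=C(C(=O)Nc2ccc([N+](=O)[O-])cc2)C(c2cccc([N+](=O)[O-])c2)N=C(SCc2ccc(Cl)cc2)N1` have each been tested in a functional assay on the whole organism (artery, strain albino) with Rattus norvegicus as the target, with a stated time of 240 min, at a dose of 10 mg/kg by the oral route; a higher number here means more inhibition at the dose given (going by the name of the read-out), a lower number less inhibition. In this assay compound 1 gives 29.2%, compound 2 gives 22.1% and compound 3 gives 20%. Compound 1 and compound 2 share one core and differ in a single place, namely (fluoro in place of chloro on an aromatic carbon). That change brought a number 7.1 percentage points lower from compound 1 to compound 2 (within the scatter), so the two readings cannot be told apart by this assay. Compound 3 is built on another core, and how that core differs from the core of compound 1 is not broken down here. Its reading and that of compound 2 lie within the scatter of each other, as do its reading and that of compound 1, so no ordering among the three compounds is claimed.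

Compound 4 `CC1=C(C(=O)Nc2ccc([N+](=O)[O-])cc2)C(c2cccc([N+](=O)[O-])c2)N=C(SCc2ccc(F)cc2)N1` has not yet been measured. It is derived from compound 3 by the same change that turns compound 1 into compound 2, namely (fluoro in place of chloro on an aromatic carbon), and the place of the change reads the same in both pairs, so this is the same change made on a different core. Because the earlier pair showed a number 7.1 percentage points lower from compound 1 to compound 2 (within the scatter), the step from compound 3 to compound 4 is expected to be a number 5 percentage points lower from compound 3 to compound 4 (within the scatter), which again stays within the scatter. This rests on a single measured pair and is therefore a thin basis. On that basis compound 4 is expected to give 15% in this assay, with a likely range from 4% to 27%.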

Compound 4, a percentage reported as inhibition, in the whole organism at one dose (the size of the read-out at that dose, not a potency): 22.6%
Compound 4: the middle estimate sits 7.6 percentage points below what was measured; low and high end bracket the measured number.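

Putting fluoro in place of chloro on the second core, which turns the 4-chlorobenzyl group into a 4-fluorobenzyl group, gave a number 2.6 percentage points higher from compound 3 to compound 4 (within the scatter), so this assay cannot tell these two readings apart. Set beside the same swap on the first core, the new step does not stand out as different: the same change on two cores in this assay, a number 7.1 percentage points lower (within the scatter) from compound 1 to compound 2 and a number 2.6 percentage points higher (within the scatter) from compound 3 to compound 4, 9.7 percentage points apart, within the scatter of two such steps. This shows that neither core gave a readable change from this swap and that nothing here speaks against treating the two cores alike, but it does not show that the swap has no effect or that it acts identically on both cores, as a real but modest difference could stay hidden in readings this scattered, and two pairs are a small sample.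

The compounds shown carry only chloro or fluoro in this place, so it remains open whether a clearly different group there, such as an amine or a carboxylic acid, would move the reading beyond the scatter. It also remains open whether either halogen would separate from the other at another dose or time point, as each compound is shown under a single set of conditions.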